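The source may report more compounds than this note shows. Statements on the series, on what has been measured and on what is new or still open speak of the compounds shown alone.

Of the compounds shown here, two have so far been measured in an assay on microsomes from Testis (strain Sprague-Dawley) for inhibition of steroid 17-alpha-hydroxylase/17,20 lyase (Rattus norvegicus); on this read-out higher numbers stand for weaker inhibition and lower numbers for stronger inhibition. Compound 1 `COC(=O)c1ccc2cc(C(O)(c3c[nH]cn3)C(C)C)ccc2c1` gives 43 nM in this assay. Compound 2 `COc1ccc2cc([C@](O)(c3c[nH]cn3)C(C)C)ccc2c1` gives 21 nM in this assay. Of these two numbers, compound 1 holds the higher one; its nearest neighbour is compound 2, whose number is lower by a margin beyond the usual scatter. Among the compounds with values here, no pair of measured compounds differs in just one place, so these two values only show where each compound stands and carry no single-change step.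

Compound 3 `CCNC(=O)c1ccc2cc(C(O)(c3c[nH]cn3)C(C)C)ccc2c1` has not yet been measured in this assay. It differs from compound 1 in one place: ethylamino in place of methoxy on a carbonyl carbon Read one bond further out, this is methoxycarbonyl giving way to ethylcarbamoyl, while the shared core and the rest of the molecule stay as they are.

Within the data shown here, with no measured step of this kind available, the expectation for compound 3 leans on compound 1 and its value of 43 nM. In this assay the step of a 1.2-fold higher number from compound 1 to compound 3 (0.07 log units; within the scatter) is expected to be small, within or only just beyond the scatter, with no firm direction. Compound 3 is therefore expected to give about 50 nM, within a range from 15 nM to 160 nM.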

Compound 3, half-maximal inhibitory concentration: 11 nM
Estimate against measurement, compound 3: 4.5-fold (0.66 log units) above; the measured number lies below the stated range.
By their numbers in this assay, from the lowest: compounds 3 and 2 (each within the scatter of the next); then compound 1.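

Replacing the methoxy on the carbonyl carbon with ethylamino, so that methoxycarbonyl becomes ethylcarbamoyl, gives in this assay a 3.9-fold lower number from compound 1 to compound 3 (0.59 log units; beyond the scatter) as a modest step beyond the scatter, which shows that the number responds to what is attached to this carbonyl. This first single-change comparison also shows that the position accepts a group of three heavy atoms in place of two, carrying a hydrogen-bond donor where the methoxy had none, and that inhibition grows stronger rather than weaker with this swap. No measured information available here bears on why the number falls, so the step stands as an observation only.

Going by these compounds, this single step cannot separate the effect of exchanging oxygen for nitrogen from the effect of the longer chain, so it remains open whether a plain amino group, methylamino or propylamino on the same carbonyl would give a similar number. On these data alone, it also remains open how a carboxylic acid at this place, or dimethylamino, which leaves no amide hydrogen, would compare with compound 3.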